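The source may hold more compounds than are shown below. What is called first, only, known or untested is meant among the compounds shown, and "the series" means these compounds.

Of the compounds shown here, three that share one core have been measured in a functional assay on HSC-4 cells (Homo sapiens) for cytotoxicity, with a stated time of 48 h; on this read-out lower numbers stand for higher toxicity in this test and higher numbers for lower toxicity in this test. Compound 1 `Cc1c(C(=O)/C=C/c2cccc([N+](=O)[O-])c2)[n+]([O-])c2ccccc2[n+]1[O-]` gives 54000 nM in this assay. Compound 2 `Cc1c(C(=O)/C=C/c2ccc(Cl)c(Cl)c2)[n+]([O-])c2ccccc2[n+]1[O-]` gives 15000 nM in this assay. Compound 3 `COc1cc(/C=C/C(=O)c2c(C)[n+]([O-])c3ccccc3[n+]2[O-])cc(OC)c1OC` gives 6500 nM in this assay. Of these three numbers, compound 2 holds the second highest. Its nearest neighbour is compound 3, whose number is lower by more than the usual scatter of repeated measurements, and its furthest neighbour is compound 1, whose number is higher by more than that scatter.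

Compound 4 `Cc1c(C(=O)/C=C/c2ccc(Br)cc2)[n+]([O-])c2ccccc2[n+]1[O-]` has not yet been measured in this assay. It differs from compound 2 in a single place: 4-bromophenyl in place of 3,4-dichlorophenyl on a double-bonded chain carbon bound to a double-bonded chain carbon. For the measured compounds named here, the three measured compounds each carry a different group at that place, and none of them differs from another in only that one place, so no measured step shows what this particular swap does. The expectation therefore rests on compound 2 alone, with 15000 nM as the starting point. The step from compound 2 to compound 4 is expected to be a 1.3-fold higher number from compound 2 to compound 4 (0.12 log units; within the scatter), a modest shift toward a higher number that may well stay within the scatter. Compound 4 is thus estimated at 20000 nM in this assay. Compound 4 is expected to fall between 8000 nM and 50000 nM.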

Compound 4, half-maximal cytotoxic concentration: 36000 nM
Compound 4: middle estimate off by 1.8-fold (0.26 log units), on the low side; measured number inside the range.
By their numbers in this assay, from the lowest: compound 3; then compound 2; then compounds 4 and 1 (each within the scatter of the next).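

In this assay, putting 4-bromophenyl in place of 3,4-dichlorophenyl gives a 2.4-fold higher number from compound 2 to compound 4 (0.38 log units; beyond the scatter) and so moves the read-out toward lower toxicity in this test, by more than repeated measurements would usually scatter. This is the first pair shown that differs in only one place, which makes it the first direct sign that the group on a double-bonded chain carbon bound to a double-bonded chain carbon can change this number while the rest of the molecule stays the same. Nothing measured here bears on why the number moves.

The swap also changes two things at once, since two chlorine atoms leave and one bromine atom enters, so this single pair cannot show whether losing chlorine or gaining bromine matters more. Plain phenyl and 4-chlorophenyl at this place would help separate those two parts of the change, while an amine or a carboxylic acid on the ring would test whether the same number responds to groups of a very different kind.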